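Chloropurine benzyl chlorides: cytotoxicity notes on four compounds

The compounds below may be only part of what the source reports. "The series", "measured", "known", "first", "only" and "open" are said of these compounds alone.

Measured so far in a functional assay on A549 cells (Homo sapiens) for cytotoxicity, read by sulforhodamine B assay, with a stated time of 48 h; on this read-out lower numbers stand for higher toxicity in this test and higher numbers for lower toxicity in this test:
compound 1 `ClCc1cccc(Cn2cnc3ncnc(Cl)c32)c1` gives 91200 nM.
compound 2 `ClCc1ccccc1Cn1cnc2ncnc(Cl)c21` sits at the assay limit of > 100000 nM, which is a limit and not a number (the limit of > 100000 nM in this assay, at which 1 of the 3 values shown sits).
compound 3 `ClCc1cccc(Cn2cnc3nc(Cl)nc(Cl)c32)c1` gives 55000 nM.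

Compound 1 and compound 2 are built from the same atoms joined differently; the difference between the two cores is not broken down here.

From compound 1 to compound 3 the change is chloro in place of hydrogen on an aromatic carbon. In this assay this gives a 1.7-fold lower number from compound 1 to compound 3 (0.22 log units; within the scatter), a step within the scatter, so the two values do not separate the compounds.

Compound 4 `ClCc1ccccc1Cn1cnc2nc(Cl)nc(Cl)c21` is not yet measured. It arises from compound 2 by chloro in place of hydrogen on an aromatic carbon, the same change as from compound 1 to compound 3, at a place described in the same words. This change occurs twice among the compounds shown, and its one measured instance stayed within the scatter.

The step from compound 2 to compound 4 in this assay is therefore expected to be about a number no higher from compound 2 to compound 4 (the limit leaves the size open), resting on the measured step of a 1.7-fold lower number from compound 1 to compound 3 (0.22 log units; within the scatter) and on compound 2 standing at the limit > 100000 nM.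

Compound 4 is expected at about 100000 nM, with a range from 40000 nM to 250000 nM, and with a substantial chance that the assay reports only a limit rather than a number.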

Compound 4, concentration lethal to 50% of the cells: > 100000 nM
Compound 4 gave a limit, no number; the forecaster's own chance of this, stated with the estimate: 55%; the middle value lies on the limit itself.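

In this assay compound 2 and compound 4 both sit at a limit rather than a number, so no step can be read between them: the limit of > 100000 nM in this assay, at which 2 of the 4 values shown sit.

The compounds shown leave open whether chloro in place of hydrogen on an aromatic carbon shifts the read-out at all when it is made on compound 2, the change that gives compound 4.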